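Side-chain swap from compound 3 to compound 4

The source may report more compounds than this note shows. Statements on the series, on what has been measured and on what is new or still open speak of the compounds shown alone.

Compound 1 `OC[C@H]1O[C@@H](n2cnc3c(CSc4ccccn4)ncnc32)[C@H](O)[C@@H]1O` gives > 100000 nM (a limit)
Compound 2 `CSCc1ncnc2c1ncn2[C@@H]1O[C@H](CO)[C@@H](O)[C@H]1O` gives 32000 nM
Compound 3 `OC[C@H]1O[C@@H](n2cnc3c(Cn4cccn4)ncnc32)[C@H](O)[C@@H]1O` gives 48000 nM

Going by the values given here, all values come from a functional assay on MT4 cells (Homo sapiens) for cytotoxicity, with a stated time of 4 days (on this read-out lower numbers stand for higher toxicity in this test and higher numbers for lower toxicity in this test), and only one comparison has numbers at both ends: a 1.5-fold higher number from compound 2 to compound 3 (0.18 log units; within the scatter), so compound 3 holds no separate rank. Compound 1 is reported only as a limit (the limit of > 100000 nM in this assay, at which 1 of the 3 values shown sits). Compound 4 `OCCSCc1ncnc2c1ncn2[C@@H]1O[C@H](CO)[C@@H](O)[C@H]1O` carries (2-hydroxyethyl)sulfanyl in place of 1H-pyrazol-1-yl ((2-hydroxyethyl)sulfanyl in place of 1H-pyrazol-1-yl on a saturated chain carbon bound to an aromatic carbon). Compound 2 is the nearest guide, as it also bears a sulfanyl group on that carbon, and its exchange with 1H-pyrazol-1-yl stayed within the scatter. Changing the group on sulfur can matter, however, given an at least 3.1-fold lower number from compound 1 to compound 2 (0.49 log units; beyond the scatter) and an at least 2.0-fold lower number from compound 1 to compound 3 (0.31 log units; beyond the scatter) in the same read-out. The expected step is a 1.0-fold higher number from compound 3 to compound 4 (0.02 log units; within the scatter), none beyond the scatter. For compound 4 the estimate is 50000 nM (expected range 20000 nM to 100000 nM).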

Compound 4, half-maximal cytotoxic concentration: > 100000 nM
Compound 4 was reported as a limit; the forecaster's own chance of this, stated with the estimate: 25%; middle value at least 2.0-fold (0.30 log units) away from the limit.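

In this assay, compound 4 is reported only as a limit: the limit of > 100000 nM in this assay, at which 2 of the 4 values shown sit. On this saturated chain carbon, the group on sulfur matters even between two small alkyl groups: hydroxymethyl in place of hydrogen on a saturated chain carbon bound to a sulfur gives an at least 3.1-fold higher number from compound 2 to compound 4 (0.49 log units; beyond the scatter), and the swap for 1H-pyrazol-1-yl gives an at least 2.0-fold higher number from compound 3 to compound 4 (0.31 log units; beyond the scatter). The step between compound 1 and compound 4 cannot be read.

Going by these compounds, whether the hydroxyl group or the added chain length carries the step stays open. An amine, a carboxylic acid or a longer chain on sulfur would separate the two.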